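Moving the methoxy group on the cinnamate aryl ring

The source may report more compounds than this note shows. Statements on the series, on what has been measured and on what is new or still open speak of the compounds shown alone.

Compound 2 `COc1cccc(/C=C/C(=O)OC/C=C/c2cc(OC)c(OC)cc2OC)c1` is an ester in which a cinnamate bearing a 3-methoxyphenyl group is joined to an allylic alcohol carrying a trimethoxyphenyl ring. In a functional assay on the whole organism (strain Kunming) with Mus musculus as the target, with a stated time of 0.5 h, at a dose of 300 mg/kg by the intraperitoneal route (on this read-out lower numbers stand for a stronger effect and higher numbers for a weaker effect at the one dose given), compound 2 gives 100%, which is the top of the read-out and means no measurable effect at the dose tested. Compound 1 `COc1cc(OC)c(OC)cc1/C=C/COC(=O)/C=C/c1cccc(Br)c1` differs only by a bromo group on the aromatic carbon; in this assay compound 1 gives 100%. The step of no change at the digits printed from compound 1 to compound 2 (within the scatter) therefore shows that exchanging bromo for methoxy left the read-out where it was, and compound 2 stands level with compound 1.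

Compound 3 `COc1ccc(/C=C/C(=O)OC/C=C/c2cc(OC)c(OC)cc2OC)cc1` keeps every atom of compound 2 and changes only where the methoxy sits: 4-methoxyphenyl in place of 3-methoxyphenyl on a double-bonded chain carbon bound to a double-bonded chain carbon. Among the compounds with values here, no measured step covers such a move, so the only guide is that compound 2 itself shows nothing, and the bromo-to-methoxy exchange also shifted nothing. On that basis the expected step of no change at the digits printed from compound 2 to compound 3 (within the scatter) is none beyond the scatter. Compound 3 is accordingly estimated at 100%, with a range from 85% to 100%.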

Compound 3, a percentage reported as activity, at one dose (the size of the read-out at that dose, not a potency): 100%
Estimate against measurement, compound 3: no gap at the digits printed, within the range that was stated.
By their numbers in this assay, from the lowest: compounds 1, 2 and 3 (each within the scatter of the next).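

Moving the methoxy group from 3-methoxyphenyl to 4-methoxyphenyl on a double-bonded chain carbon bound to a double-bonded chain carbon gives no change at the digits printed from compound 2 to compound 3 (within the scatter) in this assay and so adds a shift of the same group on the ring to the earlier exchange of one group for another. Putting 4-methoxyphenyl in place of 3-bromophenyl at that same place changes both the group and where it sits on the ring, and this gives no change at the digits printed from compound 1 to compound 3 (within the scatter) as the outcome. All three compounds rest at the top of the read-out, so neither kind of change brought out an effect at the one dose given, and no measurement is available that could explain this result.

With every value at the top of the read-out, these compounds cannot show whether the bromo and methoxy groups or their two placements would differ in a series with a measurable effect. On these data alone, it remains open whether an amine or a carboxylic acid on this ring, or a longer chain in place of the methoxy group, would lower the reading.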